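This account rests on a few compounds, and the source may have more. Where it says the series, first, only, none or still open, it means among the compounds named here.

Of the compounds shown here, two with a shared core have been measured so far in a functional assay on A549 cells (Homo sapiens) for antiproliferative activity, read by MTT assay, with a stated time of 48 h; on this read-out lower numbers stand for stronger inhibition and higher numbers for weaker inhibition. There, compound 1 `Fc1ccc2[nH]c(-c3cn(-c4ccccc4)nc3-c3ccc(Cl)cc3)nc2c1` gives 4610 nM, and compound 2 `FC(F)(F)c1ccc2[nH]c(-c3cn(-c4ccccc4)nc3-c3ccc(Cl)cc3)nc2c1` gives 3360 nM. These two values cannot be told apart, as the measured difference is a 1.4-fold lower number from compound 1 to compound 2 (0.14 log units; within the scatter). Compound 2 therefore stands level with compound 1, and no clear ranking exists yet.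

Compound 3 `Cc1ccc2[nH]c(-c3cn(-c4ccccc4)nc3-c3ccc(Cl)cc3)nc2c1` has not been measured. It differs from compound 2 in a single group, with methyl in place of trifluoromethyl on an aromatic carbon. For the measured compounds named here, only one measured step bears on this change, the step from compound 1 to compound 2 already given, and it stayed within the scatter. Going by the values given here, that is thin evidence, since no measured compound carries the methyl group. Even so, with nothing pointing to a larger shift, no step beyond the scatter is expected in this assay, and no direction can be favoured with confidence. The expected change is a 1.2-fold higher number from compound 2 to compound 3 (0.08 log units; within the scatter). The estimated value for compound 3 is 4000 nM, with an expected range from 2000 nM to 8000 nM.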

Compound 3, half-maximal inhibitory concentration: 4640 nM
The estimate for compound 3 lay 1.2-fold (0.06 log units) below the measured number; the range from low to high includes it.
By their numbers in this assay, from the lowest: compounds 2, 1 and 3 (each within the scatter of the next).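

For the compounds shown here, with compound 3, this position on the six-membered aromatic ring has now carried three different groups in this assay, which gives a first comparison that does not involve fluoro. Trifluoromethyl, with its 4 heavy atoms, gives way to methyl, with 1 heavy atom and no fluorine, and this exchange amounts to a 1.4-fold higher number from compound 2 to compound 3 (0.14 log units; within the scatter), while putting methyl in place of fluoro amounts to a 1.0-fold higher number from compound 1 to compound 3 (0.00 log units; within the scatter), so neither step leaves the usual scatter and the three groups cannot be told apart at this position. Nothing available explains why these exchanges leave the read-out within the scatter, and no measurement of any property of these compounds is at hand.

The compounds shown leave open whether this position would remain as undemanding with a group of a different kind, such as an amine, a carboxylic acid or a longer chain. Going by these compounds alone, they also leave open whether the same picture would hold if a different part of the shared core were changed, since every step so far concerns this one position.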